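Ring-nitrogen substituents in a macrocyclic hydroxamate series

The source may hold more compounds than are shown below. What is called first, only, known or untested is meant among the compounds shown, and "the series" means these compounds.

Measured so far:
compound 1 `CNC(=O)[C@@H]1CCCNCCCCO[C@H](C(=O)NO)[C@@H](CCCc2ccccc2)C(=O)N1` — 21 nM
compound 2 `CNC(=O)[C@@H]1CCCN(C(=O)OC(C)(C)C)CCCCO[C@H](C(=O)NO)[C@@H](CCCc2ccccc2)C(=O)N1` — 19 nM

Both measured compounds share the same core and differ only at the ring amine nitrogen. In an assay on isolated protein for inhibition of matrix metalloproteinase-9 (Homo sapiens) (on this read-out higher numbers stand for weaker inhibition and lower numbers for stronger inhibition), compound 1 gives 21 nM and compound 2 gives 19 nM. The step of a 1.1-fold lower number from compound 1 to compound 2 (0.04 log units; within the scatter) shows that replacing the amine hydrogen by tert-butoxycarbonyl leaves the number within the scatter, so compound 2 stands level with compound 1 on the two values available.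

Compound 3 `CNC(=O)[C@@H]1CCCN(S(=O)(=O)c2ccccc2)CCCCO[C@H](C(=O)NO)[C@@H](CCCc2ccccc2)C(=O)N1` is not yet measured. It differs from compound 2 by phenylsulfonyl in place of tert-butoxycarbonyl on an amine nitrogen in a ring. Going by the values given here, the only step bearing on this site, from compound 1 to compound 2, was within the scatter, which suggests that this ring nitrogen tolerates substitution without a change beyond the scatter. Among the compounds with values here, no measured step covers phenylsulfonyl itself, so the width of the range is large.

For compound 3 in this assay the expected value is 20 nM, range 7 nM to 60 nM. The step of a 1.1-fold higher number from compound 2 to compound 3 (0.02 log units; within the scatter) is expected to fall within the scatter.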

Compound 3, inhibition constant: 2 nM
Compound 3: middle estimate off by 10-fold (1.00 log units), on the high side; measured number outside the range, below it.
By their numbers in this assay, from the lowest: compound 3; then compounds 2 and 1 (each within the scatter of the next).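

In this assay this ring nitrogen proves sensitive to the identity of its substituent, a point the within-scatter tert-butoxycarbonyl step could not show: the change to phenylsulfonyl gives a 9.5-fold lower number from compound 2 to compound 3 (0.98 log units; beyond the scatter), and the comparison with the free amine gives an 11-fold lower number from compound 1 to compound 3 (1.02 log units; beyond the scatter). Compound 3 therefore stands apart from both compound 1 and compound 2, so substitution at this nitrogen is not uniformly neutral across the three compounds. The change brings in a six-membered aromatic ring of carbon only and a sulfur atom, with the count of hydrogen-bond acceptors unchanged, but no measurement here explains the difference.

From the compounds shown here alone, it remains open whether the step goes with the sulfonyl or with the phenyl ring; methylsulfonyl or benzoyl on the same nitrogen would separate the two. Also open, going by these compounds, is how the number responds to a methoxy or chloro group on the phenyl ring.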